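Methyl to Ethyl on the Ring Nitrogen: An Expected Limit

The compounds below may be only part of what the source reports. "The series", "measured", "known", "first", "only" and "open" are said of these compounds alone.

In a functional assay on K562 cells (Homo sapiens) for antiproliferative activity, read by MTT assay, with a stated time of 72 h (on this read-out higher numbers stand for weaker inhibition and lower numbers for stronger inhibition), compound 1 `CC1Oc2ccc(Br)cc2C=C1/C=C1\SC(=O)NC1=O` gives 77000 nM. Compound 2 `CC1Oc2ccc(Br)cc2C=C1/C=C1\SC(=O)N(C)C1=O` returns only the limit of the assay, > 50000 nM. The step that the limit leaves unreadable from compound 1 to compound 2 therefore cannot be sized, as shown by the limit of > 50000 nM in this assay, at which 1 of the 2 values shown sits. Compound 3 `CCN1C(=O)S/C(=C\C2=Cc3cc(Br)ccc3OC2C)C1=O` carries the change (methyl in place of hydrogen on a saturated chain carbon bound to an amide-type nitrogen in a ring). Going by the values given here, only that unreadable step touches this nitrogen, so it gives no direction and no size, and no step beyond the scatter is expected in this assay. Compound 3 is expected near 80000 nM, between 30000 nM and 250000 nM, most likely again only a limit. For compound 3 this amounts to an expected step that the limit leaves unreadable from compound 2 to compound 3.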

Compound 3, half-maximal inhibitory concentration: > 100000 nM
Compound 3 ended at the assay's limit; the forecaster's own chance of this, stated with the estimate: 70%; at least 1.2-fold (0.09 log units) between middle value and limit.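

Going by these compounds alone, with ethyl in place of hydrogen on the amide-type nitrogen in a ring, this assay now gives a first readable comparison at this position: an at least 1.2-fold higher number from compound 1 to compound 3 (0.11 log units; that floor lies within the scatter). That is only a floor, so no change beyond the scatter is established. The steps from hydrogen to methyl and from methyl to ethyl cannot be read, and compound 3 stands only at a limit, > 100000 nM. Going by these compounds, whether a longer chain, an amine or a carboxylic acid on this nitrogen would give a measurable value remains open.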